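The source may report more compounds than this note shows. Statements on the series, on what has been measured and on what is new or still open speak of the compounds shown alone.

Compound 1 `C/C(=N\NC(=O)/C(C#N)=C/c1ccccc1)c1c(O)c2ccc(O)cc2oc1=O` gives 15800 nM in a functional assay on HeLa cells (Homo sapiens) for cytotoxicity, read by MTT assay, with a stated time of 24 h; on this read-out higher numbers stand for weaker inhibition and lower numbers for stronger inhibition.
Compound 2 `C/C(=N\NC(=O)/C(C#N)=C/c1ccc(O)cc1)c1c(O)c2ccc(O)cc2oc1=O` gives 6020 nM in this assay.
Compound 3 `COc1cc(/C=C(\C#N)C(=O)N/N=C(\C)c2c(O)c3ccc(O)cc3oc2=O)ccc1O` gives 10500 nM in this assay.

All three share one core and differ only in the aromatic group on the double-bonded chain carbon. Compound 3 sits close to both of its neighbours: the step of a 1.5-fold lower number from compound 1 to compound 3 (0.18 log units; within the scatter) and the step of a 1.7-fold higher number from compound 2 to compound 3 (0.24 log units; within the scatter) both lie within the scatter, so compound 3 cannot be told apart from either on these numbers. Going by the values given here, only the step of a 2.6-fold lower number from compound 1 to compound 2 (0.42 log units; beyond the scatter) is clearly beyond the scatter.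

Compound 4 `C/C(=N\NC(=O)/C(C#N)=C/c1ccccc1Cl)c1c(O)c2ccc(O)cc2oc1=O` has not yet been measured. Its change from compound 3 is 2-chlorophenyl in place of 4-hydroxy-3-methoxyphenyl on a double-bonded chain carbon bound to a double-bonded chain carbon. Among the compounds with values here, two measured steps bear on it. The hydroxy group that leaves was worth the step of a 2.6-fold lower number from compound 1 to compound 2 (0.42 log units; beyond the scatter), and the whole 4-hydroxy-3-methoxyphenyl group, when it replaced phenyl, gave only a 1.5-fold lower number from compound 1 to compound 3 (0.18 log units; within the scatter). Within the data shown here, no measured step tells anything about a chlorine on the ring. Taking the hydroxy away is therefore expected to move the number back toward compound 1, while the chlorine adds uncertainty in both directions. For compound 4 the estimated step is a 1.3-fold higher number from compound 3 to compound 4 (0.12 log units; within the scatter), a small rise that may not exceed the scatter. Compound 4 is thus estimated at 14000 nM, within a range from 6000 nM to 35000 nM.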

Compound 4, half-maximal inhibitory concentration: 11800 nM
Compound 4: the middle estimate sits 1.2-fold (0.07 log units) above what was measured; measured number inside the range.
By their numbers in this assay, from the lowest: compounds 2, 3, 4 and 1 (each within the scatter of the next, the first and the last beyond it).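

Putting 2-chlorophenyl in place of 4-hydroxy-3-methoxyphenyl on this double-bonded chain carbon gives a 1.1-fold higher number from compound 3 to compound 4 (0.05 log units; within the scatter), so in this assay a ring group with 0 hydrogen-bond donors and 0 hydrogen-bond acceptors cannot be told apart from one with 1 donor and 2 acceptors. The chlorine read against the plain phenyl gives a 1.3-fold lower number from compound 1 to compound 4 (0.13 log units; within the scatter), and the swap from 4-hydroxyphenyl gives a 2.0-fold higher number from compound 2 to compound 4 (0.29 log units; within the scatter), so compound 4 lies within the scatter of both compound 1 and compound 2, even though those two lie beyond the scatter of each other, and it cannot be grouped with either one. No measurement offered here accounts for these numbers.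

As far as these compounds go, whether an amine or a carboxylic acid on the ring, or a longer chain in place of the ring, would shift the number beyond the scatter remains open. From the compounds shown here alone, with a single chlorine compound and a single step beyond the scatter, it is also open whether a ring carrying both chloro and hydroxy would follow compound 2, compound 4 or neither.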